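Sulfonyl Aryl Swap and Expected Microsomal Clearance

This account rests on a few compounds, and the source may have more. Where it says the series, first, only, none or still open, it means among the compounds named here.

Measured so far in an ADME assay on microsomes from liver (Homo sapiens) for metabolic stability, tested at 2.5 uM; a lower number here means slower removal, a higher number faster removal of the compound:
compound 1 `O=S(=O)(c1ccc(F)c(Cl)c1)c1cnc2cc(F)ccc2c1-c1ccc(Cl)cc1` gives 0.39 mL/min
compound 2 `O=S(=O)(c1cc(Cl)cc(Cl)c1)c1cnc2cc(F)ccc2c1-c1ccc(Cl)cc1` gives 0.13 mL/min

Among the measured compounds shown here, compound 2 has the lower of the two numbers, and its only neighbour is compound 1, reached by a 3.0-fold lower number from compound 1 to compound 2 (0.48 log units; beyond the scatter). Compound 3 `O=S(=O)(c1cccc(F)c1)c1cnc2cc(F)ccc2c1-c1ccc(Cl)cc1` differs from compound 2 by 3-fluorophenyl in place of 3,5-dichlorophenyl on a sulfonyl sulfur. For the measured compounds named here, the one step that bears on this change is the measured step, which exchanged one halogenated aryl on the sulfonyl sulfur for another and moved the number modestly downward. Compound 3 removes both chlorines from that aryl, so a modest rise in this assay is expected for compound 3, estimated at 0.45 mL/min with a range of 0.15 mL/min to 1.2 mL/min. The expected step is a 3.5-fold higher number from compound 2 to compound 3 (0.54 log units; beyond the scatter) for compound 3.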

Compound 3, intrinsic clearance in a liver preparation (reported as CLH), per the amount of preparation that the assay uses: 0.98 mL/min
Compound 3: middle estimate off by 2.2-fold (0.34 log units), on the low side; the measured number falls inside the stated range.
By their numbers in this assay, from the lowest: compound 2; then compound 1; then compound 3.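

Read in this assay the aryl on the sulfonyl sulfur moves the number further than the earlier pair showed: 3-fluorophenyl gives a 7.5-fold higher number from compound 2 to compound 3 (0.88 log units; beyond the scatter) against 3,5-dichlorophenyl and a 2.5-fold higher number from compound 1 to compound 3 (0.40 log units; beyond the scatter) against 3-chloro-4-fluorophenyl. Among these three aryl groups, the one without chlorine carries the highest number, and both steps lie beyond the scatter. Nothing measured here explains this order.

As far as these compounds go, whether a plain phenyl, or an aryl bearing a methoxy group or an amine, would stand nearer compound 2 or compound 3 remains open.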